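From dimethylcarbamoyl to (pyrrolidin-1-yl)carbonyl on the shared core

A few compounds are considered here, and "the series" means these few. Any claim that something is new, unique, unknown or untested is made for them only; others in the source may bear on it.

Measured in a functional assay on SW480 cells (Homo sapiens) for antiproliferative activity, read by MTT assay, with a stated time of 48 h; on this read-out lower numbers stand for stronger inhibition and higher numbers for weaker inhibition:
- compound 1 `CC(C)=CCC[C@]1(C)/C=C/[C@@H](OC(=O)C=C(C)C)[C@](C)(O)/C=C/C(=O)/C(CN=[N+]=[N-])=C\C1` gives 4230 nM 
- compound 2 `CC(C)=CCC[C@]1(C)/C=C/[C@@H](OC(=O)C=C(C)C)[C@](C)(O)/C=C/C(=O)/C(C(=O)N(C)C)=C\C1` gives 3300 nM 

Among the compounds with values here, only two compounds have been measured, and their values lie within the scatter of each other. Within the data shown here, the single measured step, a 1.3-fold lower number from compound 1 to compound 2 (0.11 log units; within the scatter), places dimethylcarbamoyl where azidomethyl stood on a double-bonded ring carbon. Compound 3 `CC(C)=CCC[C@]1(C)/C=C/[C@@H](OC(=O)C=C(C)C)[C@](C)(O)/C=C/C(=O)/C(C(=O)N2CCCC2)=C\C1` keeps the shared core and differs from compound 2 by pyrrolidin-1-yl in place of dimethylamino on a carbonyl carbon. Among the measured compounds shown here, the measured step bears on this only loosely, since it exchanged the whole group and no measured pair varies the amine part of the amide. No shift beyond the scatter is therefore expected in this assay. The expected step is a 1.1-fold lower number from compound 2 to compound 3 (0.04 log units; within the scatter) and has no firm direction. For compound 3 the estimated value is 3000 nM, with an expected range from 1300 nM to 7000 nM.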

Compound 3, half-maximal inhibitory concentration: 15100 nM
For compound 3 the middle estimate is 5.0-fold (0.70 log units) below the measured one, outside the stated range (above it).
By their numbers in this assay, from the lowest: compounds 2 and 1 (each within the scatter of the next); then compound 3.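

In this assay, the amine part of the amide on the carbonyl carbon proves to matter, which the earlier pair could not show: replacing dimethylamino with pyrrolidin-1-yl gives a 4.6-fold higher number from compound 2 to compound 3 (0.66 log units; beyond the scatter), a step beyond the scatter. Placing (pyrrolidin-1-yl)carbonyl where azidomethyl stood on the double-bonded ring carbon likewise gives a 3.6-fold higher number from compound 1 to compound 3 (0.55 log units; beyond the scatter), so the two earlier groups' agreement within the scatter does not extend to every group at this position. Nothing available explains the change. The compounds shown leave open whether the rise belongs to the ring of pyrrolidin-1-yl or simply to a larger amine part, which an open-chain diethylamino amide could separate. They also leave open how a morpholin-4-yl amide or a free carboxylic acid would read at this carbon.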